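Swapping the iodoacetamide for an isothiocyanate on compound 2

A few compounds are considered here, and "the series" means these few. Any claim that something is new, unique, unknown or untested is made for them only; others in the source may bear on it.

Two compounds have numbers in an ADME assay on the whole organism (thoracic aorta) with Rattus norvegicus as the target (a lower number here means a smaller maximal response, a higher number a larger maximal response), so far. Compound 1 `S=C=Nc1ccc(CCC2=NCCN2)cc1` gives 107% in this assay. Compound 2 `O=C(CI)Nc1ccc(CC2=NCCN2)cc1` gives 25% in this assay, the lower of the two numbers, and compound 1 stands above it by a gap beyond the usual scatter. Compound 3 `S=C=Nc1ccc(CC2=NCCN2)cc1` has not yet been measured; it differs from compound 2 in one place: a group of 3 heavy atoms (1 carbon, 1 nitrogen, 1 sulfur; no ring) in place of a group of 5 heavy atoms (2 carbon, 1 nitrogen, 1 oxygen, 1 iodine; no ring), on an aromatic carbon. The same entering group is carried by compound 1, which gives 107% in this assay, so an upward step is expected in this assay, estimated as a number 50 percentage points higher from compound 2 to compound 3 (beyond the scatter). Compound 3 is therefore expected to reach about 75%, within a range from 35% to 110%.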

Compound 3, largest response reached (Emax), in percent of the reference or control that the assay uses: 118%
Beside the measured number, compound 3's estimate is 43 percentage points below it, and the stated range ends below it.
By their numbers in this assay, from the lowest: compound 2; then compound 1; then compound 3.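

In this assay, with the ((iodomethyl)carbonyl)amino group replaced by the isothiocyanate on the aromatic carbon, the maximal response is a number 93 percentage points higher from compound 2 to compound 3 (beyond the scatter). This single change on an otherwise shared core separates a low response from a high one, which the earlier pair, differing in more than one place, could not show. No measurement shown here accounts for the size of this step. On these data alone, it remains open whether the step follows from the entering isothiocyanate or from the loss of the iodine-bearing group. As far as these compounds go, how a simple amine or an unhalogenated acetamide at this position would respond also remains open.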